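The compounds below may be only part of what the source reports. "The series", "measured", "known", "first", "only" and "open" are said of these compounds alone.

Tracking in a functional assay on SGC-7901 cells (Homo sapiens) for cytotoxicity, read by MTT assay, with a stated time of 48 h (a higher number here means a weaker inhibitor, a lower number a stronger inhibitor), is what follows the series. Compound 1 `CCN(CC)c1ccc2cc(C(=O)c3ccc(N4CCN(C(=O)CN5CCN(S(=O)(=O)c6ccc(C(F)(F)F)cc6)CC5)CC4)cc3)oc2c1` returns only a limit in this assay, > 40000 nM. Compound 2 `C#CCN1CCN(CC(=O)N2CCN(c3ccc(C(=O)c4cc5ccc(N(CC)CC)cc5o4)cc3)CC2)CC1` carries the one numerical result, 20100 nM, and so stands alone among the values shown, the other sitting at the limit of > 40000 nM in this assay, at which 1 of the 2 values shown sits. Compound 3 `CCN(CC)c1ccc2cc(C(=O)c3ccc(N4CCN(C(=O)CN5CCN(CC(C)=O)CC5)CC4)cc3)oc2c1` differs from compound 2 by acetyl in place of ethynyl on a saturated chain carbon bound to an amine nitrogen in a ring. For the measured compounds named here, no step between measured compounds is resolved, so the step expected in this assay is a 1.2-fold higher number from compound 2 to compound 3 (0.08 log units; within the scatter), none beyond the scatter. Compound 3 is estimated at 24000 nM, within 8000 nM to 70000 nM.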

Compound 3, half-maximal inhibitory concentration: 2210 nM
The estimate for compound 3 lay 11-fold (1.04 log units) above the measured number; the whole stated range lies above it.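

In this assay, for the compounds shown here, the group on the saturated chain carbon bound to an amine nitrogen in a ring clearly matters: acetyl in place of ethynyl comes with a 9.1-fold lower number from compound 2 to compound 3 (0.96 log units; beyond the scatter), the only step that can be read. The entering acetyl carries a hydrogen-bond acceptor and the leaving ethynyl does not, but one pair cannot tie the step to that difference. Nothing at hand gives a cause for this step. Open, going by these compounds, is whether a 2-hydroxypropyl or a longer chain ending in a carboxylic acid would hold the lower number at this place.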